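The source may hold more compounds than are shown below. What is called first, only, known or untested is meant among the compounds shown, and "the series" means these compounds.

Measured in a functional assay on SK-OV-3 cells (Homo sapiens) for cytotoxicity, read by MTT assay, with a stated time of 48 h; a higher number here means a weaker inhibitor, a lower number a stronger inhibitor:
- compound 1 `CN(C)CCNc1ccnc2cc(OCc3ccccc3)ccc12` gives 2350 nM
- compound 2 `Clc1ccnc2cc(OCc3ccccc3)ccc12` gives 5170 nM
- compound 3 `Fc1ccc(COc2ccc3c(Cl)ccnc3c2)cc1` gives 2780 nM

Compound 1 has the lowest number of the three in this assay. Against compound 2 the step is a 2.2-fold higher number from compound 1 to compound 2 (0.34 log units; beyond the scatter); against compound 3 the gap is within the scatter, so the two cannot be ordered.

The two measured steps both concern other parts of the molecule. The step of a 2.2-fold higher number from compound 1 to compound 2 (0.34 log units; beyond the scatter) exchanges the amine side chain for chloro on the core; the step of a 1.9-fold lower number from compound 2 to compound 3 (0.27 log units; within the scatter) adds fluoro to the benzyl ring and stays within the scatter. Neither step touches the benzyloxy group itself.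

Compound 4 `CCCCCCOc1ccc2c(NCCN(C)C)ccnc2c1` differs from compound 1 at exactly that group: pentyl in place of phenyl on a saturated chain carbon bound to an oxygen on an aromatic ring. For the measured compounds named here, no measured pair varies the benzyloxy substituent by replacement with a chain, so there is no step that bears directly on this change. Going by the values given here, the only guidance is that a change on the benzyl ring in the step of a 1.9-fold lower number from compound 2 to compound 3 (0.27 log units; within the scatter) stayed within the scatter. The expected step of a 1.1-fold higher number from compound 1 to compound 4 (0.04 log units; within the scatter) is therefore set at no change beyond the scatter, with a wide range in both directions. For compound 4 in this assay the estimate is 2600 nM, expected to lie between 900 nM and 7500 nM.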

Compound 4, half-maximal inhibitory concentration: 1860 nM
Compound 4: middle estimate off by 1.4-fold (0.15 log units), on the high side, and the stated range covers the measured number.
By their numbers in this assay, from the lowest: compounds 4, 1, 3 and 2 (each within the scatter of the next, the first and the last beyond it).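

In this assay, for the compounds shown here, the step at the benzyloxy group itself is a 1.3-fold lower number from compound 1 to compound 4 (0.10 log units; within the scatter), the first direct reading at this position: benzyloxy to hexyloxy, with the aromatic ring gone and an open chain in its place, gives no change that can be told from the scatter. The earlier compounds shown here showed only a fluoro on the benzyl ring, and that on the chloro compounds, so this pair adds that, with the (2-(dimethylamino)ethyl)amino side chain on the shared core, the phenyl ring is not needed to hold the number at this level, at least for this one pair. No measurement on hand gives a reason for this flat step.

Open, as far as these compounds go, is whether the same exchange of phenyl for pentyl would read alike on the chloro compounds, compound 2 and compound 3. Also open, from the compounds shown here alone, is how far this position stretches: a longer chain, a shorter chain such as ethyl, or a chain ending in an amine or a carboxylic acid could still move the number beyond the scatter.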